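A few compounds are considered here, and "the series" means these few. Any claim that something is new, unique, unknown or untested is made for them only; others in the source may bear on it.

Measured in a functional assay on U-937 cells (Homo sapiens) for antiproliferative activity, read by MTT assay, with a stated time of 24 h; a lower number here means a stronger inhibitor of growth, a higher number a weaker inhibitor of growth:
compound 1 `Cc1ccc(NC(=O)Nc2cc(Cl)cc(Cl)c2)cc1NC(=O)c1cnoc1C` gives > 30000 nM
compound 2 `Cc1cc(NC(=O)Nc2cccc(Cl)c2)ccc1NC(=O)c1cnoc1C` gives > 30000 nM

Both results sit at the same limit: the limit of > 30000 nM in this assay, at which 2 of the 2 values shown sit. Compound 2 stands at > 30000 nM, which is a limit of the assay and not a number. Compound 1 gives > 30000 nM, also a limit.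

Compound 3 `Cc1cc(NC(=O)Nc2ccc(Cl)c(Cl)c2)ccc1NC(=O)c1cnoc1C` is compound 2 with chloro in place of hydrogen on an aromatic carbon, ortho to the chloro group already present and para to a large group. This takes 3-chlorophenyl to 3,4-dichlorophenyl: chloro in place of hydrogen on an aromatic carbon.

Among the compounds with values here, the series offers no step between measured compounds, so the size of this change has no measured precedent. In this assay, no step beyond the scatter is expected, and a small gain in growth inhibition is the only departure considered. A further result reported only as a limit is the likeliest outcome. The expected step is a number no higher from compound 2 to compound 3 (the limit leaves the size open). Compound 3 is estimated at 30000 nM. The expected range for compound 3 runs from 10000 nM to 50000 nM.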

Compound 3, concentration for 50% growth inhibition: > 30000 nM
Compound 3: a limit, no number; the forecaster's own chance of this, stated with the estimate: 75%; the middle value sits exactly at the limit.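

Compound 3 gives > 30000 nM, which is a limit of the assay and not a number. The step from compound 2 to compound 3 therefore cannot be read, because all results sit at one limit: the limit of > 30000 nM in this assay, at which 3 of the 3 values shown sit.

The compounds shown leave open whether chloro in place of hydrogen on an aromatic carbon alters growth inhibition at all.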